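The compounds below may be only part of what the source reports. "The series", "measured", "known", "first", "only" and "open" are said of these compounds alone.

Compound 1 `CC(NC(=O)C#Cc1ccc(NC(=O)Nc2cc(C(F)(F)F)ccc2Cl)cc1)c1ccccc1` and compound 2 `CC(NC(=O)C#Cc1ccc(NC(=O)Nc2ccc(Cl)c(C(F)(F)F)c2)cc1)c1ccccc1` share a core; in a functional assay on HT-29 cells (Homo sapiens) for inhibition, read by MTT assay, with a stated time of 120 h (a higher number here means a weaker inhibitor, a lower number a stronger inhibitor), compound 1 gives 3170 nM and compound 2 gives 4920 nM. The change 4-chloro-3-(trifluoromethyl)phenyl in place of 2-chloro-5-(trifluoromethyl)phenyl on an amide-type nitrogen produced a 1.6-fold higher number from compound 1 to compound 2 (0.19 log units; within the scatter). Compound 3 `CC(NC(=O)c1ccc(-c2ccc(NC(=O)Nc3cc(C(F)(F)F)ccc3Cl)cc2)cc1)c1ccccc1` is built on a different core; the difference between the two cores is not broken down here. In this assay compound 3 gives 6570 nM, a weaker inhibitor than compound 1, while compound 3 and compound 2 lie within the scatter of each other. Compound 4 `CC(NC(=O)c1ccc(-c2ccc(NC(=O)Nc3ccc(Cl)c(C(F)(F)F)c3)cc2)cc1)c1ccccc1` is not yet measured; it carries the same change, (4-chloro-3-(trifluoromethyl)phenyl in place of 2-chloro-5-(trifluoromethyl)phenyl on an amide-type nitrogen), on the same place. For compound 4 a step of a 1.4-fold higher number from compound 3 to compound 4 (0.16 log units; within the scatter) is expected, resting on compound 1 to compound 2 having given a 1.6-fold higher number from compound 1 to compound 2 (0.19 log units; within the scatter). Compound 4 is therefore estimated at 9500 nM, with a range from 4500 nM to 20000 nM.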

Compound 4, half-maximal inhibitory concentration: 5960 nM
The estimate for compound 4 lay 1.6-fold (0.20 log units) above the measured number; the range from low to high includes it.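

In this assay, 4-chloro-3-(trifluoromethyl)phenyl in place of 2-chloro-5-(trifluoromethyl)phenyl on the second core gave a 1.1-fold lower number from compound 3 to compound 4 (0.04 log units; within the scatter), so the two groups cannot be told apart on this core. Set beside the earlier step, the change shows no detectable dependence on the core: the same change on two cores in this assay, a 1.6-fold higher number (0.19 log units; within the scatter) from compound 1 to compound 2 and a 1.1-fold lower number (0.04 log units; within the scatter) from compound 3 to compound 4, 1.7-fold (0.23 log units) apart, within the scatter of two such steps. Within the data shown here, both steps lie within the scatter, so this shows only that the change stays small on these two cores; it does not show that a larger effect would carry across, and one pair per core supports no general rule.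

Both groups carry the same chlorine and trifluoromethyl substituents. Open, going by these compounds, is whether a nitrile or a carboxylic acid in place of the trifluoromethyl would give a step large enough to test transfer between the cores.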